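A new group on the amide-type nitrogen

The source may hold more compounds than are shown below. What is called first, only, known or untested is meant among the compounds shown, and "the series" means these compounds.

Compound 1 `COc1cc2c(Oc3ccc(NC(=O)Nc4ccccc4Cl)cc3)ccnc2cc1OCCCCCCC(=O)NO` gives 1910 nM
Compound 2 `COc1cc2c(Oc3ccc(NC(=O)Nc4ccccc4C(F)(F)F)cc3)ccnc2cc1OCCCCCCC(=O)NO` gives 5280 nM
Compound 3 `COc1cc2c(Oc3ccc(NC(=O)Nc4ccc(C)cc4C)cc3)ccnc2cc1OCCCCCCC(=O)NO` gives 5490 nM

In a functional assay on A549 cells (Homo sapiens) for antiproliferative activity, read by MTT assay (on this read-out lower numbers stand for stronger inhibition and higher numbers for weaker inhibition), compound 3 at 5490 nM sits level with compound 2 at the weak end of this set, while compound 1 is the strongest. Compound 4 `COc1cc2c(Oc3ccc(NC(=O)N/N=C/c4ccccc4F)cc3)ccnc2cc1OCCCCCCC(=O)NO` brings one change: a group of 9 heavy atoms (7 carbon, 1 nitrogen, 1 fluorine; one six-membered aromatic ring of carbon only) in place of a group of 8 heavy atoms (8 carbon; one six-membered aromatic ring of carbon only), on an amide-type nitrogen and the new group holds one double bond outside aromatic rings. Two measured swaps at that nitrogen offer a guide: a 2.9-fold higher number from compound 1 to compound 3 (0.46 log units; beyond the scatter) and a 1.0-fold higher number from compound 2 to compound 3 (0.02 log units; within the scatter) are both small. Neither swap brings in such a double bond, so the guide is loose. Going by these compounds, no step beyond the scatter is therefore expected, and the direction stays open. The estimated step is a 1.6-fold lower number from compound 3 to compound 4 (0.20 log units; within the scatter) and no more than that is expected. For compound 4 the estimated value is 3500 nM with an expected range of 1000 nM to 12000 nM.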

Compound 4, half-maximal inhibitory concentration: 7780 nM
Compound 4: middle estimate off by 2.2-fold (0.35 log units), on the low side, and the stated range covers the measured number.
By their numbers in this assay, from the lowest: compound 1; then compounds 2, 3 and 4 (each within the scatter of the next).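

In this assay, the new group on the amide-type nitrogen, with its double bond outside aromatic rings, gives a number close to those of the 2,4-dimethylphenyl and 2-(trifluoromethyl)phenyl compounds: a 1.4-fold higher number from compound 3 to compound 4 (0.15 log units; within the scatter) and a 1.5-fold higher number from compound 2 to compound 4 (0.17 log units; within the scatter) both lie within the scatter. Only the 2-chlorophenyl compound stands apart, with a 4.1-fold higher number from compound 1 to compound 4 (0.61 log units; beyond the scatter) beyond the scatter. Nothing measured here bears on the reason for these numbers.

Going by these compounds, the separate shares of the double bond, the added nitrogen and the fluorine in this result stay open. So does the effect of an amine or a carboxylic acid on the aromatic ring of the new group.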